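The compounds below may be only part of what the source reports. "The series", "measured", "known", "first", "only" and "open" are said of these compounds alone.

Measured so far: compound 1 `CCN(Cc1ccc(Br)cc1)c1ccc(C(=O)N2CCc3ccc(OS(N)(=O)=O)cc3C2)cc1`, 78.2%; compound 2 `NS(=O)(=O)Oc1ccc2c(c1)CN(C(=O)c1ccc(N(CCCO)Cc3ccccc3)cc1)CC2`, 5.7%.

In an assay on HEK293 cells for inhibition of Steryl-sulfatase (Homo sapiens), tested at 0.1 uM (a higher number here means a stronger effect of the compound at the concentration tested, a lower number a weaker effect), compound 1 stands highest of the two numbers, and compound 2 lies far below it, a gap well beyond the usual scatter. Compound 3 `CCCN(CCC)c1ccc(C(=O)N2CCc3ccc(OS(N)(=O)=O)cc3C2)cc1` has not yet been measured. Its change from compound 1 is dipropylamino in place of (4-bromobenzyl)(ethyl)amino on an aromatic carbon. Among the compounds with values here, with no measured step of this kind to lean on, a fall in this assay beyond the scatter is expected, though a smaller one than the gap to compound 2. Compound 3 is therefore expected to give about 40%, within 15% to 68%, an expected step of a number 38.2 percentage points lower from compound 1 to compound 3 (beyond the scatter).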

Compound 3, a percentage reported as inhibition, at one concentration (the size of the read-out at that concentration, not a potency): 36.6%
Estimate against measurement, compound 3: 3.4 percentage points above; the measured number falls inside the stated range.
By their numbers in this assay, from the lowest: compound 2; then compound 3; then compound 1.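

In this assay, the group on this aromatic carbon clearly matters: dipropylamino in place of (4-bromobenzyl)(ethyl)amino gives a number 41.6 percentage points lower from compound 1 to compound 3 (beyond the scatter). Yet compound 3 still gives 36.6%, so a measurable effect remains with no ring in this group. No measured evidence explains the drop. Going by these compounds, the change removes the ring, the bromine and the ethyl chain together, so their separate contributions stay unknown. Benzyl(ethyl)amino, without bromine, or diethylamino, a shorter pair of chains, would help separate them.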